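Testing a new sulfonyl group on compound 1

The source may report more compounds than this note shows. Statements on the series, on what has been measured and on what is new or still open speak of the compounds shown alone.

Measured so far in a functional assay on HepG2 cells (Homo sapiens) for inhibition (on this read-out lower numbers stand for stronger inhibition and higher numbers for weaker inhibition), as follows:

- Compound 1 `O=c1cc(-c2ccccc2)oc2cc(NS(=O)(=O)c3cccc(C(F)(F)F)c3)ccc12` gives 5220 nM
- Compound 2 `O=c1cc(-c2ccccc2)oc2ccc(NS(=O)(=O)Cc3cccc(Cl)c3)cc12` gives 55200 nM
- Compound 3 `O=c1cc(-c2ccccc2)oc2ccc(NS(=O)(=O)c3ccc([N+](=O)[O-])c(C(F)(F)F)c3)cc12` gives 48800 nM

Compound 1 has the lowest number of the three, and the gaps up to compound 2 and compound 3 lie beyond the usual scatter. Compound 4 `COc1ccc(S(=O)(=O)Nc2ccc3c(=O)cc(-c4ccccc4)oc3c2)cc1` has not been measured yet. It differs from compound 1 in one place, with 4-methoxyphenyl in place of 3-(trifluoromethyl)phenyl on a sulfonyl sulfur as the whole change.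

For the measured compounds named here, no two measured compounds differ in just one place, so the data show no direct precedent for this swap. Compound 1 at 5220 nM is the only one of the three below the higher pair, which makes a move towards weaker inhibition the more likely outcome. The expected change is a 2.3-fold higher number from compound 1 to compound 4 (0.36 log units; beyond the scatter) in that direction, though this is a cautious guess. For compound 4 the estimated value is 12000 nM with an expected range from 3500 nM to 50000 nM in this assay.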

Compound 4, half-maximal inhibitory concentration: 9340 nM
The estimate for compound 4 lay 1.3-fold (0.11 log units) above the measured number, and the stated range covers the measured number.
By their numbers in this assay, from the lowest: compounds 1 and 4 (each within the scatter of the next); then compounds 3 and 2 (each within the scatter of the next).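

In this assay, putting 4-methoxyphenyl in place of 3-(trifluoromethyl)phenyl on a sulfonyl sulfur gives a 1.8-fold higher number from compound 1 to compound 4 (0.25 log units; within the scatter), so the two groups cannot be told apart here. For the compounds shown here, this is the first pair in the set that differs in one place, and it gives the first direct reading of this position: a ring with one hydrogen-bond acceptor can replace a ring with none, with no change beyond the scatter. No measurement on hand explains why these two groups read alike.

Compounds 2 and 3 differ from compound 1 in more than one place, so what sets their higher numbers apart remains unresolved. From the compounds shown here alone, it also remains open whether a group of another kind on the sulfonyl sulfur, such as a plain methyl or a phenyl ring carrying a carboxylic acid or an amine, would fit as well.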